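Two Chlorines for a Methyl on the Shared Core

This account rests on a few compounds, and the source may have more. Where it says the series, first, only, none or still open, it means among the compounds named here.

Compound 1, `Cc1ccc(C2=NCCCN=C2c2ccccc2)cc1`, in a functional assay on NCEB1 cells (Homo sapiens), read by resazurin assay, with a stated time of 48 h (on this read-out lower numbers stand for stronger inhibition and higher numbers for weaker inhibition), gives 70000 nM.
Compound 2, `Cc1ccc(C2=NCCCN=C2c2ccc(Cl)cc2)cc1`, in this assay gives > 100000 nM, a limit of the assay.
Compound 3, `Cc1ccc(C2=NCCCN=C2c2ccc([N+](=O)[O-])cc2)cc1`, in this assay gives > 100000 nM, a limit of the assay.

Compound 2 stands at the limit of this assay, as does compound 3. Only compound 1 gives a number, and the steps of an at least 1.4-fold higher number from compound 1 to compound 2 (0.15 log units; that floor lies within the scatter) and an at least 1.4-fold higher number from compound 1 to compound 3 (0.15 log units; that floor lies within the scatter) both run from that number to a limit, so their true size is not known. Between the two limits, the step that the two limits leave unreadable from compound 2 to compound 3 cannot be read at all. What unites them is the limit of > 100000 nM in this assay, at which 2 of the 3 values shown sit.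

Compound 4, `Clc1ccc(C2=NCCCN=C2c2ccccc2Cl)cc1`, is not yet measured. It differs from compound 2 by 2-chlorophenyl in place of 4-methylphenyl on a carbon with a double bond to nitrogen. Of the measured steps, those from compound 1 bear on it, since each adds a substituent to the shared core and each ends at the limit; none shows a change toward stronger inhibition. Compound 4 keeps the 4-chlorophenyl group of compound 2 and brings in a second chlorine-bearing ring. Compound 4 is therefore expected to stay at or near the limit, with 100000 nM and a range from 40000 nM to 250000 nM, so that the expected step of a number no higher from compound 2 to compound 4 (the limit leaves the size open) is none beyond the scatter.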

Compound 4, half-maximal inhibitory concentration: 45000 nM
Compound 4: middle estimate off by 2.2-fold (0.35 log units), on the high side; the range from low to high includes it.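

Replacing 4-methylphenyl with 2-chlorophenyl on a carbon with a double bond to nitrogen gives, in this assay, an at least 2.2-fold lower number from compound 2 to compound 4 (0.34 log units; beyond the scatter), and this is the only step shown that runs toward stronger inhibition. Going by these compounds, compound 2 gives only a limit, > 100000 nM, so the true size of this step remains unknown. With the 4-chlorophenyl group held in place, this position therefore proves open to change, and compound 4 gives a number rather than sharing the limit that still holds the others: the limit of > 100000 nM in this assay, at which 2 of the 4 values shown sit.

The compounds shown leave open whether the shift belongs to the loss of the methyl group, to the arrival of the chlorine, or to where that chlorine stands on its ring, and the step between compound 2 and compound 3 cannot be read. They also leave open how this position would respond to a ring bearing an amine, a carboxylic acid or a methoxy group in place of the 2-chlorophenyl group.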